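The source may hold more compounds than are shown below. What is called first, only, known or untested is meant among the compounds shown, and "the series" means these compounds.

Three compounds built on one shared core were tested in a functional assay on HT-29 cells (Homo sapiens) for cytotoxicity, read by MTT assay, with a stated time of 24 h, tested at 80 ug/mL; on this read-out higher numbers stand for a stronger effect at the one concentration tested and lower numbers for a weaker effect. Compound 1 `Cn1c(-c2ccc(NC(=O)CCl)cc2)nc(-c2ccccc2)c1-c1ccccc1` gives 76.1%. Compound 2 `Cn1nnnc1SCC(=O)Nc1ccc(-c2nc(-c3ccccc3)c(-c3ccccc3)n2C)cc1` gives 89% in this assay, and compound 3 `CCN1CCN(CC(=O)Nc2ccc(-c3nc(-c4ccccc4)c(-c4ccccc4)n3C)cc2)CC1` gives 51.2%. On these numbers compound 3 stands lowest of the three: the move from compound 1 to compound 3 was a number 24.9 percentage points lower from compound 1 to compound 3 (beyond the scatter), and the move from compound 2 to compound 3 was a number 37.8 percentage points lower from compound 2 to compound 3 (beyond the scatter), both beyond the scatter.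

Compound 4 `CN(C)/C=C/N1CCN(CC(=O)Nc2ccc(-c3nc(-c4ccccc4)c(-c4ccccc4)n3C)cc2)CC1` has not yet been measured. It differs from compound 3 in one place: 2-(dimethylamino)ethenyl in place of ethyl on an amine nitrogen in a ring. Among the compounds with values here, none of the measured steps touches this place. All three of them exchanged the group on a saturated chain carbon bound to a carbonyl carbon, and they show that exchanges there can shift the number by modest to large amounts, as in a number 12.9 percentage points higher from compound 1 to compound 2 (beyond the scatter). Nothing measured tells what an exchange on the amine nitrogen in the ring does, so the expectation rests on compound 3 alone, with wide uncertainty. The expected step is a number 1.2 percentage points lower from compound 3 to compound 4 (within the scatter), which would lie within the usual scatter. The estimate for compound 4 in this assay is 50%, ranging from 30% to 70%.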

Compound 4, a percentage reported as activity, at one concentration (the size of the read-out at that concentration, not a potency): 45.4%
Beside the measured number, compound 4's estimate is 4.6 percentage points above it; measured number inside the range.
By their numbers in this assay, from the lowest: compounds 4 and 3 (each within the scatter of the next); then compound 1; then compound 2.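

In this assay, within the data shown here, placing 2-(dimethylamino)ethenyl instead of ethyl on the amine nitrogen in the ring gives a number 5.8 percentage points lower from compound 3 to compound 4 (within the scatter), the first reading at this position. On these two compounds, a group of 5 heavy atoms with a double bond and a group of 2 heavy atoms cannot be told apart on this nitrogen. The new piperazine group also keeps the large gaps to the other compounds, with 4-(2-(dimethylamino)ethenyl)piperazin-1-yl in place of chloro giving a number 30.7 percentage points lower from compound 1 to compound 4 (beyond the scatter) and the same group in place of (1-methyl-1H-tetrazol-5-yl)sulfanyl giving a number 43.6 percentage points lower from compound 2 to compound 4 (beyond the scatter); no available evidence offers a reason for these numbers.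

From the compounds shown here alone, one exchange cannot describe the whole position, so it remains open whether a hydrogen, an acetyl group, a benzyl group or a longer chain on this nitrogen would also stay as close to compound 3. Going by these compounds, it is equally open whether another amine on the chain carbon, such as morpholine or dimethylamino, would fall with the two piperazine compounds or closer to compound 2.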